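This account rests on a few compounds, and the source may have more. Where it says the series, first, only, none or still open, it means among the compounds named here.

Working notes on the series. Compound 3 `COc1ccccc1C(=O)Nc1sc2c(c1C(N)=O)CCN(C(=S)Nc1ccccc1Cl)C2` gives 20800 nM in a functional assay on HL-60 cells (Homo sapiens) for antiproliferative activity, with a stated time of 24 h; on this read-out higher numbers stand for weaker inhibition and lower numbers for stronger inhibition; compound 1 `Cc1ccc(C(=O)Nc2sc3c(c2C(N)=O)CCN(Cc2ccc(Cl)cc2Cl)C3)cc1` gives 19900 nM and compound 2 `NC(=O)c1c(NC(=O)c2ccccc2)sc2c1CCN(C(=S)Nc1ccccc1Cl)C2` gives 13800 nM, so all three lie within the scatter of one another and no ordering among them can be read. Among the measured compounds shown here, the only single-point step available, a 1.5-fold higher number from compound 2 to compound 3 (0.18 log units; within the scatter), adds a methoxy and stays within the scatter. Compound 4 `Cc1ccc(C(=O)Nc2sc3c(c2C(N)=O)CCN(C(=S)Nc2ccccc2Cl)C3)cc1` differs from compound 3 by 4-methylphenyl in place of 2-methoxyphenyl on a carbonyl carbon. Compound 1 already carries the 4-methylphenyl on the same carbonyl, though with a different group on the ring nitrogen, and its number sits beside those of compound 2 and compound 3. No shown step therefore points to a change beyond the scatter, and the expected step from compound 3 to compound 4 is a 1.2-fold lower number from compound 3 to compound 4 (0.09 log units; within the scatter). Compound 4 is estimated at 17000 nM, in the range 7000 nM to 40000 nM.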

Compound 4, half-maximal inhibitory concentration: 8430 nM
Compound 4: middle estimate off by 2.0-fold (0.30 log units), on the high side; low and high end bracket the measured number.
By their numbers in this assay, from the lowest: compounds 4, 2, 1 and 3 (each within the scatter of the next, the first and the last beyond it).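

In this assay, the carbonyl carbon proves able to move the number beyond the scatter, with 4-methylphenyl in place of 2-methoxyphenyl giving a 2.5-fold lower number from compound 3 to compound 4 (0.39 log units; beyond the scatter). The plain phenyl on the same carbonyl does not separate from 4-methylphenyl, as methyl in place of hydrogen gives only a 1.6-fold lower number from compound 2 to compound 4 (0.21 log units; within the scatter). With the 4-methylphenyl held constant, the group on the amine nitrogen in a ring also counts, at a 2.4-fold lower number from compound 1 to compound 4 (0.37 log units; beyond the scatter).

Nothing available explains these steps. On these data alone, whether an amine or a carboxylic acid in place of the 4-methylphenyl on the carbonyl carbon would hold the lower number stays open.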